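The source may hold more compounds than are shown below. What is called first, only, known or untested is meant among the compounds shown, and "the series" means these compounds.

Compound 1 `O=C(O)[C@H](CO)NC(=O)[C@H]1C[C@H](O)CN1`: > 12 h
Compound 2 `O=C(N[C@H](CO)C(=O)O)[C@@H]1C[C@H](O)CN1`: > 12 h
Compound 3 `O=C(N[C@H](CO)C(=O)O)[C@@H]1C[C@@H](O)CN1`: 0.91 h

All three values come from an ADME assay (Mus musculus, strain C57BL/6) for metabolic stability, read by HPLC, with a stated time of 12 h; on this read-out lower numbers stand for a shorter-lived compound and higher numbers for a longer-lived compound. Compound 1 has a value of > 12 h, which is a limit of the assay and not a number. Compound 2 has a value of > 12 h, which is also only a limit. Compound 2 therefore stands at the limit of > 12 h in this assay, at which 2 of the 3 values shown sit, so any step away from it can be read only in part.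

Compound 4 `O=C(O)[C@H](CO)NC(=O)[C@@H]1C[C@@H](O)CN1` has not yet been measured. Its difference from compound 2 is the two compounds have the same atoms and bonds and differ only in configuration as drawn: 2 of 3 stereo elements differ; a stereocentre at a saturated chain carbon is drawn R in compound 2 and S in compound 4; a stereocentre at a saturated ring carbon is drawn S in compound 2 and R in compound 4: a stereocentre at a saturated chain carbon is drawn R in compound 2 and S in compound 4, and a stereocentre at a saturated ring carbon is drawn S in compound 2 and R in compound 4.

The best guide is an at least 13-fold lower number from compound 2 to compound 3 (1.12 log units; beyond the scatter), a large step beyond the scatter. Given (the fact that compounds 2 and 3 differ only in the configuration as drawn), that step rests on a single ring stereocentre going from S to R, a change that compound 4 also carries. The chain change is harder to judge, since a step that the two limits leave unreadable from compound 1 to compound 2 includes a chain inversion but cannot be sized. an at least 13-fold lower number from compound 1 to compound 3 (1.12 log units; beyond the scatter) is also large, but there every stereocentre is inverted.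

A large fall is therefore expected, and the expected step is an at least 15-fold lower number from compound 2 to compound 4 (1.17 log units; beyond the scatter). For compound 4 the estimated half-life is 0.8 h, with an expected range of 0.2 h to 3.5 h.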

Compound 4, half-life: 0.86 h
The estimate for compound 4 lay 1.1-fold (0.03 log units) below the measured number; the range from low to high includes it.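

In this assay, among these compounds, the chain stereocentre can now be read on its own for the first time, and a 1.1-fold lower number from compound 3 to compound 4 (0.02 log units; within the scatter) shows that inverting it makes no difference that stands out from the scatter while the ring carbon stays drawn R: the fact that compounds 3 and 4 differ only in the configuration as drawn. The large falls in half-life persist with the chain carbon drawn either way, as an at least 13-fold lower number from compound 2 to compound 4 (1.14 log units; beyond the scatter) and an at least 13-fold lower number from compound 1 to compound 4 (1.14 log units; beyond the scatter), and both of these steps start from a compound held at a limit of the assay, so their true size may be greater. Across the four compounds, the two short-lived ones, compound 3 and compound 4, share the ring carbon drawn R, while compound 1 and compound 2 carry it drawn S, and no compound shown goes against this pattern, although compound 1 also differs from compound 4 at the other ring stereocentre.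

On these data alone, the limits shared by compound 1 and compound 2 leave it unknown whether the other ring stereocentre, or the chain stereocentre, matters when this ring carbon is drawn S. Also open is whether the pattern would survive a change of atoms rather than of configuration, such as a methyl ester in place of the carboxylic acid or a fluorine in place of the ring hydroxyl.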